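Aryl swap on the ring nitrogen: cytotoxicity working notes

The compounds below may be only part of what the source reports. "The series", "measured", "known", "first", "only" and "open" are said of these compounds alone.

Measured compounds in an ADME assay on HT-29 cells (Homo sapiens) for cytotoxicity, read by MTT assay, with a stated time of 72 h; on this read-out higher numbers stand for weaker inhibition and lower numbers for stronger inhibition:
- compound 1 `C=CC(=O)Nc1cc(Nc2ncc3ncn(-c4ccc(C(C)C)cc4)c3n2)c(OC)cc1N(C)CCN(C)C`: compound 1 gives 15300 nM
- compound 2 `C=CC(=O)Nc1cc(Nc2ncc3ncn(-c4ccc(CC)cc4)c3n2)c(OC)cc1N(C)CCN(C)C`: compound 2 gives 8180 nM
- compound 3 `C=CC(=O)Nc1cc(Nc2ncc3ncn(-c4ccc(I)cc4)c3n2)c(OC)cc1N(C)CCN(C)C`: compound 3 gives 9520 nM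

Compound 3 stands second highest of the three numbers; its nearest neighbour is compound 2, separated by a 1.2-fold higher number from compound 2 to compound 3 (0.07 log units; within the scatter), and its furthest is compound 1, separated by a 1.6-fold lower number from compound 1 to compound 3 (0.21 log units; within the scatter). All three values therefore sit within the scatter of one another, and no ordering is claimed among them.

Compound 4 `C=CC(=O)Nc1cc(Nc2ncc3ncn(-c4ccc(F)c(Cl)c4)c3n2)c(OC)cc1N(C)CCN(C)C` differs from compound 3 by 3-chloro-4-fluorophenyl in place of 4-iodophenyl on an aromatic nitrogen. For the measured compounds named here, the steps that bear on this position are a 1.9-fold lower number from compound 1 to compound 2 (0.27 log units; within the scatter), a 1.6-fold lower number from compound 1 to compound 3 (0.21 log units; within the scatter) and a 1.2-fold higher number from compound 2 to compound 3 (0.07 log units; within the scatter); each lies within the scatter, so changing the group on the aromatic nitrogen of the five-membered aromatic ring has so far not moved this assay beyond its noise. The same is expected for the step to compound 4: no change beyond the scatter, a 1.0-fold lower number from compound 3 to compound 4 (0.00 log units; within the scatter). Compound 4 is estimated at 9500 nM, with a range from 4000 nM to 22000 nM.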

Compound 4, half-maximal inhibitory concentration: 1610 nM
The estimate for compound 4 lay 5.9-fold (0.77 log units) above the measured number; the whole stated range lies above it.
By their numbers in this assay, from the lowest: compound 4; then compounds 2, 3 and 1 (each within the scatter of the next).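

In this assay, the group on the aromatic nitrogen of the five-membered aromatic ring does move the read-out: the change to 3-chloro-4-fluorophenyl gives steps beyond the scatter, though modest, against all three earlier compounds (a 5.9-fold lower number from compound 3 to compound 4 (0.77 log units; beyond the scatter); a 5.1-fold lower number from compound 2 to compound 4 (0.71 log units; beyond the scatter); a 9.5-fold lower number from compound 1 to compound 4 (0.98 log units; beyond the scatter)). Compound 4 therefore has the lowest number of the four, while 4-isopropylphenyl, 4-ethylphenyl and 4-iodophenyl remain within the scatter of one another, so this position is not indifferent to the aryl group it carries. No measurement at hand bears on what lies behind this step.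

It remains open which of the two halogens of 3-chloro-4-fluorophenyl accounts for the step, a question that 3-chlorophenyl and 4-fluorophenyl would address on this read-out. Also open, from the compounds shown here alone, is how a phenyl ring carrying an amine or a carboxylic acid would read at the same aromatic nitrogen.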